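The source may hold more compounds than are shown below. What is called first, only, known or untested is meant among the compounds shown, and "the series" means these compounds.

Measured so far:
compound 1, `CCC(/C=C(\COC(C)=O)C(=O)c1ccccc1)CC`: 52000 nM
compound 2, `CC(=O)OC/C(=C\c1ccccc1)C(=O)c1ccccc1`: 17000 nM

In a functional assay on WiDr cells (Homo sapiens) for inhibition, read by sulforhodamine B assay, with a stated time of 48 h (a lower number here means a stronger inhibitor of growth, a higher number a weaker inhibitor of growth), compound 2 gives 17000 nM, the lowest of the two numbers; its nearest neighbour is compound 1, which in this assay gives 52000 nM. Going by the values given here, the only measured step, a 3.1-fold lower number from compound 1 to compound 2 (0.49 log units; beyond the scatter), put phenyl in place of pentan-3-yl on the double-bonded chain carbon. Compound 3, `CC(=O)OC/C(=C\c1ccc(Cl)cc1)C(=O)c1ccccc1`, is not yet measured. It differs from compound 2 by chloro in place of hydrogen on an aromatic carbon, on an aromatic carbon of a six-membered aromatic ring of carbon only, para to a large group. Among the compounds with values here, no measured pair tests a chloro on this ring, so the step of a 3.1-fold lower number from compound 1 to compound 2 (0.49 log units; beyond the scatter) bears on it only by showing that changes at this end of the chain move the number modestly. For compound 3 the step is therefore expected to be small, a 1.4-fold lower number from compound 2 to compound 3 (0.15 log units; within the scatter), possibly none beyond the scatter. Compound 3 is expected to give 12000 nM in this assay, with a range from 4000 nM to 35000 nM.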

Compound 3, concentration for 50% growth inhibition: 4800 nM
Compound 3: middle estimate off by 2.5-fold (0.40 log units), on the high side, and the stated range covers the measured number.
By their numbers in this assay, from the lowest: compound 3; then compound 2; then compound 1.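

In this assay, the ring brought in by compound 2 proves open to further change: adding one chlorine atom, chloro in place of hydrogen para to a large group, gives a 3.5-fold lower number from compound 2 to compound 3 (0.55 log units; beyond the scatter). That single atom moves the number about as far as replacing the whole pentan-3-yl group did, which gave a 3.1-fold lower number from compound 1 to compound 2 (0.49 log units; beyond the scatter). The full replacement of pentan-3-yl by 4-chlorophenyl therefore gives an 11-fold lower number from compound 1 to compound 3 (1.03 log units; beyond the scatter), and nothing available explains why chloro has this effect.

As far as these compounds go, it remains open whether the gain is specific to chloro or would also come with fluoro, bromo, methyl or methoxy at the same carbon, and whether chloro would do the same on another carbon of the ring. The acetate is the same in all three compounds, so replacing it with a free alcohol or an amine remains an open question.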